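The source may hold more compounds than are shown below. What is called first, only, known or untested is meant among the compounds shown, and "the series" means these compounds.

In a functional assay on MCF7 cells (Homo sapiens) for cytotoxicity, read by MTT assay, with a stated time of 72 h (on this read-out lower numbers stand for stronger inhibition and higher numbers for weaker inhibition), three compounds with a shared core have been measured. Compound 1 `O=C(/C=C/c1ccc([N+](=O)[O-])cc1)Nc1cc2c(Nc3ccc(F)c(Cl)c3)ncnc2cc1O[C@H]1CCOC1` gives 26700 nM, compound 2 `COc1ccc(OC)c(/C=C/C(=O)Nc2cc3c(Nc4ccc(F)c(Cl)c4)ncnc3cc2OC)c1` gives 34300 nM, and compound 3 `COc1cc2ncnc(Nc3ccc(F)c(Cl)c3)c2cc1NC(=O)/C=C/c1ccccc1[N+](=O)[O-]` gives 36500 nM. The number for compound 3 thus stands within the scatter of both others, and the three cannot be ranked.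

Compound 4 `COc1cc(/C=C/C(=O)Nc2cc3c(Nc4ccc(F)c(Cl)c4)ncnc3cc2OC)cc(OC)c1` departs from compound 3 in one place: 3,5-dimethoxyphenyl in place of 2-nitrophenyl on a double-bonded chain carbon bound to a double-bonded chain carbon. Here 3,5-dimethoxyphenyl takes the place of 2-nitrophenyl on a double-bonded chain carbon bound to a double-bonded chain carbon.

Within the data shown here, one measured step bears on this change. It joins a dimethoxyphenyl compound to the same 2-nitrophenyl compound, and it is a 1.1-fold higher number from compound 2 to compound 3 (0.03 log units; within the scatter). Among the measured compounds shown here, no measured compound carries 3,5-dimethoxyphenyl, so this remains an indirect guide, and the estimate is kept wide. In this assay, the expected change is a 1.2-fold lower number from compound 3 to compound 4 (0.09 log units; within the scatter), so no step beyond the scatter is anticipated. Compound 4 is estimated at 30000 nM, with an expected range from 12000 nM to 60000 nM.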

Compound 4, half-maximal inhibitory concentration: 38500 nM
Compound 4: the middle estimate sits 1.3-fold (0.11 log units) below what was measured; the range from low to high includes it.
By their numbers in this assay, from the lowest: compounds 1, 2, 3 and 4 (each within the scatter of the next).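

In this assay, the change from 2-nitrophenyl to 3,5-dimethoxyphenyl on a double-bonded chain carbon bound to a double-bonded chain carbon gives a 1.1-fold higher number from compound 3 to compound 4 (0.02 log units; within the scatter) and so stays within the scatter. Among these compounds, the first comparison of two dimethoxyphenyl groups at this place, 2,5-dimethoxyphenyl and 3,5-dimethoxyphenyl, gives a 1.1-fold higher number from compound 2 to compound 4 (0.05 log units; within the scatter), so the three groups now measured here on the shared core cannot be told apart. Nothing measured accounts for this lack of separation.

The compounds shown leave open whether an amine or a carboxylic acid on this phenyl ring would give a step beyond the scatter. They also leave open whether a longer chain in place of the ethenyl link would do so.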